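Removing one methoxy group from compound 2

A few compounds are considered here, and "the series" means these few. Any claim that something is new, unique, unknown or untested is made for them only; others in the source may bear on it.

In a functional assay on CCRF-CEM cells (Homo sapiens) for cytotoxicity, read by sulforhodamine B assay, with a stated time of 48 h, tested at 10 uM (a higher number here means a weaker effect of the compound at the concentration tested, a lower number a stronger effect), compound 1 `COc1ccc(-c2cc(/C=C/C(=O)c3ccc(N)cc3)[nH]n2)cc1` gives -27%, and compound 2 `COc1cc(-c2cc(/C=C/C(=O)c3ccc(N)cc3)[nH]n2)cc(OC)c1OC` gives -22%. Compound 2 stands highest of the two numbers shown, though its gap to compound 1 lies within the scatter. Compound 3 `COc1ccc(-c2cc(/C=C/C(=O)c3ccc(N)cc3)[nH]n2)cc1OC` has not yet been measured; it differs from compound 2 in one place: hydrogen in place of methoxy on an aromatic carbon. Going by the values given here, no step between measured compounds is available, and compound 1 and compound 2 read alike, so no change beyond the scatter is expected, making the estimated step of a number 3 percentage points lower from compound 2 to compound 3 (within the scatter) small. Compound 3 is expected to give -25%, with a range from -45% to -5%.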

Compound 3, a percentage reported as activity, at one concentration (the size of the read-out at that concentration, not a potency): -8%
Compound 3: middle estimate off by 17 percentage points, on the low side; measured number inside the range.
By their numbers in this assay, from the lowest: compounds 1 and 2 (each within the scatter of the next); then compound 3.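

In this assay, hydrogen in place of methoxy on an aromatic carbon gives a number 14 percentage points higher from compound 2 to compound 3 (beyond the scatter) and methoxy in place of hydrogen gives a number 19 percentage points higher from compound 1 to compound 3 (beyond the scatter) so compound 3 shows the weakest effect of the three. A methoxy group removed and a methoxy group added thus both move the number the same way, and the count of methoxy groups does not order these compounds in one direction. Nothing given here accounts for this. As far as these compounds go, whether a hydroxyl group, a fluorine or an ethoxy group on this carbon would restore the stronger effect remains open.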